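The compounds below may be only part of what the source reports. "The series", "measured", "known", "first", "only" and "open" are said of these compounds alone.

Working notes on the series. The shared core is that of compound 1 `COc1ccc(C2=NO[C@]3(C2)C(=O)O[C@@H]2[C@H]3CC[C@H](C)[C@]3(O)C=CC(=O)[C@@]23C)cc1`, which in a functional assay on SW-620 cells (Homo sapiens) for cytotoxicity, read by sulforhodamine B assay, with a stated time of 48 h (on this read-out higher numbers stand for weaker inhibition and lower numbers for stronger inhibition), gives 41000 nM. Compound 2 `C[C@H]1CC[C@@H]2[C@@H](OC(=O)[C@]23CC(c2ccc(N(C)C)cc2)=NO3)[C@]2(C)C(=O)C=C[C@@]12O` gives 5100 nM in this assay, and compound 3 `C[C@H]1CC[C@@H]2[C@@H](OC(=O)[C@]23CC(c2ccc([N+](=O)[O-])cc2)=NO3)[C@]2(C)C(=O)C=C[C@@]12O` gives 9000 nM. Compound 2 stands lowest of the three numbers: its nearest neighbour is compound 3, with a 1.8-fold higher number from compound 2 to compound 3 (0.25 log units; within the scatter), and its furthest is compound 1, with an 8.0-fold lower number from compound 1 to compound 2 (0.91 log units; beyond the scatter).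

Compound 4 `Cc1cccc(C2=NO[C@]3(C2)C(=O)O[C@@H]2[C@H]3CC[C@H](C)[C@]3(O)C=CC(=O)[C@@]23C)c1` has not yet been measured; it differs from compound 2 by 3-methylphenyl in place of 4-(dimethylamino)phenyl on a carbon with a double bond to nitrogen. Within the data shown here, the steps that bear on this change are the earlier replacements of the aromatic substituent: an 8.0-fold lower number from compound 1 to compound 2 (0.91 log units; beyond the scatter) and a 4.6-fold lower number from compound 1 to compound 3 (0.66 log units; beyond the scatter), both modest and beyond the scatter, while a 1.8-fold higher number from compound 2 to compound 3 (0.25 log units; within the scatter) lies within the scatter. Only three aromatic substituents are covered, and none without a hydrogen-bond acceptor, so the outcome for 3-methylphenyl is uncertain. Since compound 1 gives 41000 nM and compound 2 gives 5100 nM, a modest move back toward the higher number is expected. For compound 4 the estimated step is a 3.9-fold higher number from compound 2 to compound 4 (0.59 log units; beyond the scatter). Compound 4 is expected to give 20000 nM, with a range of 6000 nM to 60000 nM.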

Compound 4, half-maximal inhibitory concentration: 15000 nM
Beside the measured number, compound 4's estimate is 1.3-fold (0.12 log units) above it; the range from low to high includes it.
By their numbers in this assay, from the lowest: compounds 2, 3 and 4 (each within the scatter of the next, the first and the last beyond it); then compound 1.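

In this assay, 3-methylphenyl, with no hydrogen-bond acceptor, still gives a 2.7-fold lower number from compound 1 to compound 4 (0.44 log units; beyond the scatter), so the drop from the number of compound 1 does not depend on an acceptor in the group on this carbon with a double bond to nitrogen. The same change gives a 2.9-fold higher number from compound 2 to compound 4 (0.47 log units; beyond the scatter), beyond the scatter, and a 1.7-fold higher number from compound 3 to compound 4 (0.22 log units; within the scatter), within it, so 3-methylphenyl separates from 4-(dimethylamino)phenyl but not from 4-nitrophenyl. No measurement at hand accounts for these differences.

The methyl group in compound 4 differs from the other substituents in both identity and ring position, and 4-methylphenyl would be needed to separate these two changes. Also open, as far as these compounds go, is what a carboxylic acid on the phenyl ring, or a cyclohexyl group in place of it, would give.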